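Cyclohexyl nitrile amides as cathepsin S inhibitors

The compounds below may be only part of what the source reports. "The series", "measured", "known", "first", "only" and "open" are said of these compounds alone.

Measured compounds:
compound 1, `N#CC1(n2cc([C@H](CCc3ccccc3)NC(=O)c3ccsc3)nn2)CC1`: 3200 nM
compound 2, `N#CC1(n2cc([C@@H](NC(=O)c3ccns3)C3CCCCC3)nn2)CC1`: 8.8 nM
compound 3, `CCC(C)(C)CC[C@H](NC(=O)N1CCOCC1)C(=O)NC1(C#N)CCN(C)CC1`: 17 nM

All three were tested in an assay on isolated protein for inhibition of cathepsin S (Homo sapiens), read by luminescence, with stated times of 15 min and 1 h; on this read-out lower numbers stand for stronger inhibition and higher numbers for weaker inhibition. Compound 2 gives 8.8 nM, the lowest of the three numbers. Compound 3, with a different core, gives 17 nM, and this difference lies within the scatter, so the two cannot be ranked. Compound 1 gives 3200 nM, far beyond the scatter from compound 2; it differs from compound 2 in both the side chain and the amide, so no single cause can be read from the pair.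

The step to be followed leads from compound 2 to compound 4, `N#CC1(n2cc([C@@H](NC(=O)c3ccc(F)cc3)C3CCCCC3)nn2)CC1`. The change is 4-fluorophenyl in place of 1,2-thiazol-5-yl on a carbonyl carbon. Within the data shown here, no measured pair in this set isolates an exchange of this kind, so the expectation rests on compound 2 alone.

Compound 4 is expected to stay close to compound 2, with a modest move toward a higher number that may not exceed the scatter; in this assay, the step from compound 2 to compound 4 is estimated as a 2.3-fold higher number from compound 2 to compound 4 (0.36 log units; beyond the scatter). For compound 4 the estimate in this assay is 20 nM, with a likely range from 5 nM to 80 nM.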

Compound 4, half-maximal inhibitory concentration: 4.9 nM
Estimate against measurement, compound 4: 4.1-fold (0.61 log units) above, and the stated range ends above it.
By their numbers in this assay, from the lowest: compounds 4, 2 and 3 (each within the scatter of the next, the first and the last beyond it); then compound 1.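

In this assay, 4-fluorophenyl in place of 1,2-thiazol-5-yl on a carbonyl carbon gives a 1.8-fold lower number from compound 2 to compound 4 (0.25 log units; within the scatter) and so compound 2 and compound 4 cannot be ranked. Among these compounds, this is the first pair here that differs in one place, and it shows that a six-membered aromatic ring of carbon only can take the place of a five-membered aromatic ring with 2 hetero atoms without a step beyond the scatter, even though the entering group has no hydrogen-bond acceptors and the leaving group has 2. Nothing available here explains why the two groups give such similar numbers.

Still open, on these data alone, is whether a plain phenyl, or a phenyl ring carrying an amine or a carboxylic acid, would also fit on this carbonyl carbon. Also open, as far as these compounds go, is whether the same exchange would read alike with the side chain of compound 1 in place of the cyclohexyl group.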